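The compounds below may be only part of what the source reports. "The series", "measured", "known", "first", "only" and "open" are said of these compounds alone.

Compound 1 (`CN1CCC(C(=O)N2Cc3c(NC(=O)c4ccc5ccccc5c4)n[nH]c3C2(C)C)CC1`): 219000 nM
Compound 2 (`CC(C)(C)C(=O)N1Cc2c(NC(=O)c3ccc(F)cc3)n[nH]c2C1(C)C`): 235000 nM
Compound 3 (`CN1CCC(C(=O)N2Cc3c(NC(=O)c4ccsc4)n[nH]c3C2(C)C)CC1`): > 225000 nM (a limit of the assay, not a number)

These three compounds were measured in a physicochemical assay for solubility, at pH 7 (a higher number here means a more soluble compound, a lower number a less soluble compound), and the numbers for compound 1 and compound 2 lie within the scatter of each other. Compound 3 has no number of its own and stands only at a limit (the limit of > 225000 nM in this assay, at which 1 of the 3 values shown sits).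

Compound 4 (`CN1CCC(C(=O)N2Cc3c(NC(=O)Nc4cccc(F)c4)n[nH]c3C2(C)C)CC1`) has not yet been measured. It differs from compound 3 by one change ((3-fluorophenyl)amino in place of thiophen-3-yl on a carbonyl carbon), with (3-fluorophenyl)amino in place of thiophen-3-yl on a carbonyl carbon.

For the measured compounds named here, only one measured step bears on this change, as it also exchanges a group on a carbonyl carbon. That step, thiophen-3-yl in place of naphthalen-2-yl, is an at least 1.0-fold higher number from compound 1 to compound 3 (0.01 log units; that floor lies within the scatter) and offers only a floor. Going by the values given here, compound 2 offers no step that differs in one place. With so little to go on, no step beyond the scatter is expected in this assay for compound 4, though a number rather than a limit may well be returned. The expected step is small (an at least 1.1-fold lower number from compound 3 to compound 4 (0.05 log units; that floor lies within the scatter)). Compound 4 is estimated at 200000 nM (expected range 100000 nM to 270000 nM).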

Compound 4, solubility: > 225000 nM
Compound 4 was reported as a limit; the forecaster's own chance of this, stated with the estimate: 35%; middle value at least 1.1-fold (0.05 log units) away from the limit.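

For the compounds shown here, at the carbonyl carbon whose other neighbour is an amide-type nitrogen, the earlier compounds carried only aromatic rings joined directly to that carbon; (3-fluorophenyl)amino now places a ring there through a nitrogen and brings a hydrogen-bond donor that thiophen-3-yl lacks. In this assay, compound 4 has no number of its own and, like compound 3, stands only at a limit of the assay: the limit of > 225000 nM in this assay, at which 2 of the 4 values shown sit. The exchange of naphthalen-2-yl for (3-fluorophenyl)amino gives an at least 1.0-fold higher number from compound 1 to compound 4 (0.01 log units; that floor lies within the scatter), so this comparison offers only a floor, while the step between the two limits cannot be read and the change from (thiophen-3-yl)carbonyl to (3-fluorophenyl)carbamoyl has no readable size.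

From the compounds shown here alone, how far the true solubility of compound 3 and compound 4 lies beyond the limit stays unknown, so these two compounds cannot be placed relative to each other. Going by these compounds, it also stays open whether a saturated alkyl chain or a carboxylic acid on this carbonyl carbon would return a number, and what size of step it would give.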